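The source may report more compounds than this note shows. Statements on the series, on what has been measured and on what is new or still open speak of the compounds shown alone.

In a functional assay on MCF7 cells (Homo sapiens) for antiproliferative activity, read by MTT assay, with a stated time of 48 h (on this read-out lower numbers stand for stronger inhibition and higher numbers for weaker inhibition), compound 1 `O=C(/C=C/c1cccc(NC(=O)c2ccccc2Cl)c1)c1nc2ccccc2[nH]1` gives 4570 nM, compound 2 `O=C(Nc1cccc(/C=C/C(=O)c2nc3ccccc3[nH]2)c1)c1ccc(Cl)cc1` gives 8410 nM, and compound 3 `O=C(Nc1cccc(/C=C/C(=O)c2nc3ccccc3[nH]2)c1)c1cccc(Br)c1` gives 5210 nM. Compound 3 stands second highest of the three numbers; its nearest neighbour is compound 1, and a 1.1-fold higher number from compound 1 to compound 3 (0.06 log units; within the scatter), while a 1.6-fold lower number from compound 2 to compound 3 (0.21 log units; within the scatter). Both steps lie within the scatter, as does a 1.8-fold higher number from compound 1 to compound 2 (0.26 log units; within the scatter). Compound 4 `O=C(Nc1cccc(/C=C/C(=O)c2nc3ccccc3[nH]2)c1)c1cccc(C(F)(F)F)c1` differs from compound 3 in one place: trifluoromethyl in place of bromo on an aromatic carbon. Within the data shown here, no measured step swaps a bromo for a trifluoromethyl, so the three steps bear on it only indirectly: they show that exchanging one halogenated phenyl for another moves this assay by little. For compound 4 a step of similar size is therefore expected, with no clear direction: a 1.1-fold higher number from compound 3 to compound 4 (0.02 log units; within the scatter). Compound 4 is estimated at 5500 nM, within 2500 nM to 12000 nM.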

Compound 4, half-maximal inhibitory concentration: 21500 nM
Beside the measured number, compound 4's estimate is 3.9-fold (0.59 log units) below it; measured number outside the range, above it.
By their numbers in this assay, from the lowest: compounds 1, 3 and 2 (each within the scatter of the next); then compound 4.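

In this assay, among these compounds, the change from bromo to trifluoromethyl on this aromatic carbon is the first one to move the number beyond the scatter (a 4.1-fold higher number from compound 3 to compound 4 (0.62 log units; beyond the scatter)). Compound 4 also separates from the two chlorinated compounds (a 2.6-fold higher number from compound 2 to compound 4 (0.41 log units; beyond the scatter); a 4.7-fold higher number from compound 1 to compound 4 (0.67 log units; beyond the scatter)), so this position does not tolerate every substituent as evenly as the halogen exchanges among compound 1, compound 2 and compound 3 suggested. No evidence here bears on the reason for this step. As far as these compounds go, whether a methoxy group, an amine or a carboxylic acid on this carbon would give a number near compound 3 or near compound 4 stays open.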